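Replacing 2-chlorophenyl in compound 2 with 2-hydroxy-4-methylphenyl

A few compounds are considered here, and "the series" means these few. Any claim that something is new, unique, unknown or untested is made for them only; others in the source may bear on it.

Compound 1 `Cc1ncc([N+](=O)[O-])n1CCSc1nnc(-c2ccc(F)cc2)o1` gives 5300 nM
Compound 2 `Cc1ncc([N+](=O)[O-])n1CCSc1nnc(-c2ccccc2Cl)o1` gives 32600 nM

Both compounds were tested in a functional assay on SGC-7901 cells (Homo sapiens) for cytotoxicity, read by MTT assay, with a stated time of 48 h (a lower number here means a stronger inhibitor, a higher number a weaker inhibitor), and compound 2 holds the higher of the two numbers, which makes it the weaker inhibitor of the pair. Compound 3 `Cc1ccc(-c2nnc(SCCn3c([N+](=O)[O-])cnc3C)o2)c(O)c1` has not yet been measured. It carries 2-hydroxy-4-methylphenyl in place of 2-chlorophenyl on an aromatic carbon of a five-membered aromatic ring with 2 nitrogen and 1 oxygen (2-hydroxy-4-methylphenyl in place of 2-chlorophenyl on an aromatic carbon). Among the measured compounds shown here, only one measured step bears on this place, and it is modest: a 6.2-fold higher number from compound 1 to compound 2 (0.79 log units; beyond the scatter) on exchanging 4-fluorophenyl for 2-chlorophenyl. Given that step, and with compound 2 at 32600 nM as the top of the range so far, a move of similar or smaller size towards a lower number is expected. The estimated change is a 2.3-fold lower number from compound 2 to compound 3 (0.37 log units; beyond the scatter) in this reading. Compound 3 is expected at 14000 nM (estimated range 4000 nM to 45000 nM).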

Compound 3, half-maximal inhibitory concentration: 36700 nM
Compound 3: middle estimate off by 2.6-fold (0.42 log units), on the low side; the range from low to high includes it.
By their numbers in this assay, from the lowest: compound 1; then compounds 2 and 3 (each within the scatter of the next).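

In this assay the exchange of 2-chlorophenyl for 2-hydroxy-4-methylphenyl on this aromatic carbon gives a 1.1-fold higher number from compound 2 to compound 3 (0.05 log units; within the scatter) and so separates neither compound from the other, although the entering group adds a hydrogen-bond donor and a hydrogen-bond acceptor. Against 4-fluorophenyl the same group gives a 6.9-fold higher number from compound 1 to compound 3 (0.84 log units; beyond the scatter) in the same assay, which leaves compound 1 apart from two differently substituted phenyl groups. No measured evidence accounts for these numbers.

Going by these compounds, what remains open is whether the lower number of compound 1 depends on the fluorine itself or on where the group sits on the phenyl ring. A 4-chlorophenyl or 2-fluorophenyl group would address that question, and a 4-aminophenyl group would extend it to a basic amine.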